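The compounds below may be only part of what the source reports. "The series", "measured", "known", "first", "only" and "open" are said of these compounds alone.

Working notes on the series

In a toxicity assay on WI-38 cells (Homo sapiens) for cytotoxicity, read by MTT assay, with a stated time of 48 h (on this read-out higher numbers stand for weaker inhibition and lower numbers for stronger inhibition), compound 1 `O=C(/C=C/c1ccc2c(c1)B(O)OC2)c1ccccc1` gives 19100 nM. Compound 2 `CSc1ccc(C(=O)/C=C/c2ccc3c(c2)B(O)OC3)cc1` gives 54300 nM in this assay. Compound 3 `O=C(/C=C/c1ccc2c(c1)B(O)OC2)c1ccc(O)cc1` reaches only a limit of this assay, > 100000 nM, so no number is known for it. That puts compound 3 at the limit of > 100000 nM in this assay, at which 1 of the 3 values shown sits, with an at least 5.2-fold higher number from compound 1 to compound 3 (0.71 log units; beyond the scatter) and an at least 1.8-fold higher number from compound 2 to compound 3 (0.26 log units; that floor lies within the scatter) leading there.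

Compound 4 `O=C(/C=C/c1ccc2c(c1)B(O)OC2)c1ccc(C(F)(F)F)cc1` differs from compound 3 by trifluoromethyl in place of hydroxy on an aromatic carbon. Among the measured compounds shown here, no measured step involves a trifluoromethyl group. For the measured compounds named here, the steps that bear on the change are those that alter the group on that aromatic carbon: a 2.8-fold higher number from compound 1 to compound 2 (0.45 log units; beyond the scatter) and an at least 5.2-fold higher number from compound 1 to compound 3 (0.71 log units; beyond the scatter), each raising the number relative to the unsubstituted compound 1, and an at least 1.8-fold higher number from compound 2 to compound 3 (0.26 log units; that floor lies within the scatter), whose floor lies within the scatter. Going by the values given here, with no direct precedent, compound 4 is expected to land within the span that compound 1 and compound 2 mark out rather than beyond it. The expected step is an at least 2.2-fold lower number from compound 3 to compound 4 (0.34 log units; beyond the scatter), downward from the limit. The estimate for compound 4 in this assay is 45000 nM, with a range from 15000 nM to 150000 nM.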

Compound 4, half-maximal inhibitory concentration: 22600 nM
Beside the measured number, compound 4's estimate is 2.0-fold (0.30 log units) above it; measured number inside the range.
By their numbers in this assay, from the lowest: compounds 1 and 4 (each within the scatter of the next); then compound 2. At a limit, above all of these: compound 3.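

Para to a large group, trifluoromethyl is the only substituent shown that leaves the number in this assay where the unsubstituted core puts it: a 1.2-fold higher number from compound 1 to compound 4 (0.07 log units; within the scatter). A substituent at this position therefore does not raise the number in every case, as methylsulfanyl and hydroxy alone had suggested, and the outcome depends on which group is present, with a 2.4-fold lower number from compound 2 to compound 4 (0.38 log units; beyond the scatter). The change from hydroxy gives an at least 4.4-fold lower number from compound 3 to compound 4 (0.64 log units; beyond the scatter), which can be read only as a floor, as compound 3 stands at a limit: the limit of > 100000 nM in this assay, at which 1 of the 4 values shown sits.

As far as these compounds go, whether an amine, a carboxylic acid or a longer alkyl chain at this position would stay level with compound 1 or raise the number remains open. Four compounds also do not show which feature of the entering group sets the number in this assay.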